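This account rests on a few compounds, and the source may have more. Where it says the series, first, only, none or still open, it means among the compounds named here.

Of the compounds shown here, three sharing one core have been measured in a functional assay on HL-60 cells (Homo sapiens) for inhibition, read by sulforhodamine B assay, with a stated time of 48 h, tested at 10 uM; a higher number here means more inhibition at the concentration tested (going by the name of the read-out), a lower number less inhibition. Compound 1 `O=Cc1ccc(-c2cn3ccnc3c(-c3ccc4ncn(C5CCCCC5)c4c3)n2)cc1` gives 16.5% in this assay. Compound 2 `c1cn2cc(-c3ccsc3)nc(-c3ccc4ncn(C5CCCCC5)c4c3)c2n1` gives 18.5% in this assay. Compound 3 `CC(=O)c1ccc(-c2cn3ccnc3c(-c3ccc4ncn(C5CCCCC5)c4c3)n2)cc1` gives 2.65% in this assay, the lowest of the three numbers, with compound 1 the nearest and compound 2 the furthest. The steps into compound 3 were a number 13.9 percentage points lower from compound 1 to compound 3 (beyond the scatter) and a number 15.9 percentage points lower from compound 2 to compound 3 (beyond the scatter), whereas the step of a number 2 percentage points higher from compound 1 to compound 2 (within the scatter) stayed within the scatter. Compound 4 `Clc1ccc(-c2cn3ccnc3c(-c3ccc4ncn(C5CCCCC5)c4c3)n2)cc1` is not yet measured; it differs from compound 3 by chloro in place of acetyl on an aromatic carbon. Both steps into compound 3 carried a modest loss beyond the scatter, and the change to compound 4 removes the acetyl that arrived in those steps, so the relevant evidence points back toward the numbers of compound 1 and compound 2. For compound 4 a step of a number 13.4 percentage points higher from compound 3 to compound 4 (beyond the scatter) in this assay is therefore expected. The estimate for compound 4 is 16%, with a range from 5% to 28%.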

Compound 4, a percentage reported as inhibition, at one concentration (the size of the read-out at that concentration, not a potency): 15.6%
For compound 4 the middle estimate is 0.4 percentage points above the measured one, within the range that was stated.
By their numbers in this assay, from the lowest: compound 3; then compounds 4, 1 and 2 (each within the scatter of the next).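

In this assay, chloro in place of acetyl, on an aromatic carbon para to a large group, gave a number 13 percentage points higher from compound 3 to compound 4 (beyond the scatter), so the low number of compound 3 does not extend to every substituted phenyl at this position. Chloro also matches the other two groups, with a number 0.9 percentage points lower from compound 1 to compound 4 (within the scatter) and a number 2.9 percentage points lower from compound 2 to compound 4 (within the scatter), which leaves acetyl as the only group of the four set apart, even though the formyl of compound 1 also carries a carbonyl. Nothing available here explains why acetyl alone stands apart.

The compounds shown leave open whether a longer ketone such as propanoyl would behave like acetyl. They also leave open whether an amine or a carboxylic acid at this position would give a number clearly above those of compound 1, compound 2 and compound 4.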